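The source may report more compounds than this note shows. Statements on the series, on what has been measured and on what is new or still open speak of the compounds shown alone.

Measured so far:
compound 1 `COc1cc(C)cc(-c2c(-c3ccnc(-c4ccc(C(C)=O)cc4)c3)cnn2CC#N)c1`, in a functional assay on OVCAR-4 cells (Homo sapiens) for cytotoxicity, read by sulforhodamine B assay, with a stated time of 48 h, tested at 100 nM; on this read-out higher numbers stand for a weaker effect at the one concentration tested and lower numbers for a stronger effect: 105%
compound 2 `Cc1cc(O)cc(-c2nn(CC#N)cc2-c2ccnc(-c3ccc(Oc4ccccc4)cc3)c2)c1`, in this assay: 106%

Compound 2 and compound 1 lie within the scatter of each other in this assay, so the two numbers cannot be ranked; both show no effect beyond the scatter at the one concentration tested. Compound 3 `Cc1cc(O)cc(-c2nn(CC#N)cc2-c2ccnc(-c3ccc(N(C)C)cc3)c2)c1` differs from compound 2 by dimethylamino in place of phenoxy on an aromatic carbon. Among the measured compounds shown here, no step between measured compounds is available to lean on; with both measured numbers alike, the step of a number 3 percentage points lower from compound 2 to compound 3 (within the scatter) is expected to stay within the scatter, in no particular direction. Compound 3 is accordingly estimated at 103%, with a range from 90% to 115%.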

Compound 3, a percentage reported as activity, at one concentration (the size of the read-out at that concentration, not a potency): 101%
Estimate against measurement, compound 3: 2 percentage points above, within the range that was stated.
By their numbers in this assay, from the lowest: compounds 3, 1 and 2 (each within the scatter of the next).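

On an aromatic carbon para to a large group, dimethylamino in place of phenoxy gives a number 5 percentage points lower from compound 2 to compound 3 (within the scatter) in this assay. Losing the six-membered aromatic ring of the phenoxy group therefore does not separate the two compounds on this read-out, and neither group shows an effect beyond the scatter at the one concentration tested. No measured property bears on this result. As far as these compounds go, whether a carboxylic acid, a primary amine or a longer chain at this position would give a number beyond the scatter stays open.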